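A few compounds are considered here, and "the series" means these few. Any claim that something is new, unique, unknown or untested is made for them only; others in the source may bear on it.

In an ADME assay on cells (Fibroblast, Homo sapiens) for cytotoxicity, read by cell counting, with a stated time of 48 h (a higher number here means a weaker inhibitor, a lower number a stronger inhibitor), compound 1 `Cc1ccc(-n2cc(COc3cccc4cnc(Nc5cccc(Cl)c5)nc34)nn2)c([N+](=O)[O-])c1` gives 21000 nM as its measured value. Compound 2 `Clc1ccc(-n2cc(COc3cccc4cnc(Nc5cccc(Cl)c5)nc34)nn2)cc1` shows > 25000 nM there, which is a limit of the assay and not a number. Compound 3 `COc1ccccc1-n1cc(COc2cccc3cnc(Nc4cccc(Cl)c4)nc23)nn1` keeps the shared core and changes one group (2-methoxyphenyl in place of 4-chlorophenyl on an aromatic nitrogen): 2-methoxyphenyl stands in place of 4-chlorophenyl on an aromatic nitrogen. Within the data shown here, the only measured step at this place (an at least 1.1-fold higher number from compound 1 to compound 2 (0.07 log units; that floor lies within the scatter)) swapped another pair of groups, and its floor gives no firm size to carry over. Among the measured compounds shown here, no step beyond the scatter is therefore expected in this assay from this change, and compound 3 should sit close to compound 1, whose 21000 nM is the only true number so far. The expected step is an at least 1.1-fold lower number from compound 2 to compound 3 (0.05 log units; that floor lies within the scatter) in size. The estimated value for compound 3 is 22000 nM (range 10000 nM to 45000 nM).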

Compound 3, half-maximal inhibitory concentration: > 25000 nM
Compound 3: no number, only a limit (the forecaster's own chance of this, stated with the estimate: 45%); middle value at least 1.1-fold (0.05 log units) away from the limit.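

On this aromatic nitrogen, 2-methoxyphenyl carries a hydrogen-bond acceptor where 4-chlorophenyl carries none, yet compound 3, like compound 2, ends in a limit of the assay and not a number. Among these compounds, the one step that can be read is an at least 1.1-fold higher number from compound 1 to compound 3 (0.07 log units; that floor lies within the scatter), and that floor shows no change beyond the scatter, though the real size could be larger. The step between compound 2 and compound 3 cannot be read, because both stop at the same limit: the limit of > 25000 nM in this assay, at which 2 of the 3 values shown sit.

As far as these compounds go, what stays open is how far past that limit these two compounds truly lie, and whether 4-methyl-2-nitrophenyl is alone among such groups in giving a true number. Also open, from the compounds shown here alone, is what a phenyl ring bearing an amine or a carboxylic acid would give at this place.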